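This account rests on a few compounds, and the source may have more. Where it says the series, first, only, none or still open, it means among the compounds named here.

Measured so far in a functional assay on ECa-109 cells (Homo sapiens) for antiproliferative activity, read by MTT assay, with a stated time of 72 h; a lower number here means a stronger inhibitor, a higher number a weaker inhibitor:
- compound 1 `CCCSc1nc(N/N=C(\C)c2ccccc2O)c2nnn(Cc3ccc(F)cc3)c2n1` gives 21900 nM
- compound 2 `CCCSc1nc(N/N=C(\C)c2ccccc2O)c2nnn(Cc3ccccc3)c2n1` gives 11100 nM

Going by the values given here, compound 2 stands at one of only two numbers so far in this assay, and the other belongs to compound 1. Among the compounds with values here, the single step between them, a 2.0-fold lower number from compound 1 to compound 2 (0.30 log units; within the scatter), is the only comparison available, and it lies within the scatter, so the two compounds cannot be told apart on these numbers.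

Compound 3 `CCCSc1nc(N/N=C(\C)c2ccccc2O)c2nnn(Cc3ccco3)c2n1` is the next member. It differs from compound 2 by furan-2-yl in place of phenyl on a saturated chain carbon bound to an aromatic nitrogen. Within the data shown here, the one measured step, from compound 1 to compound 2, also concerns the group on the saturated chain carbon bound to the aromatic nitrogen, but it changes only a substituent on the phenyl rather than exchanging the ring itself; it was within the scatter. Among the measured compounds shown here, no measured pair shows a ring exchange of this kind, so there is nothing to set a direction from. The working expectation is therefore a step of a 1.0-fold lower number from compound 2 to compound 3 (0.00 log units; within the scatter) that stays within the scatter, and compound 3 is estimated at 11000 nM in this assay, with a range from 4000 nM to 30000 nM.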

Compound 3, half-maximal inhibitory concentration: 5760 nM
Compound 3: the middle estimate sits 1.9-fold (0.28 log units) above what was measured, within the range that was stated.
By their numbers in this assay, from the lowest: compounds 3, 2 and 1 (each within the scatter of the next, the first and the last beyond it).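

In this assay, the group on the saturated chain carbon bound to an aromatic nitrogen now tolerates exchange of the ring itself, not only a change of substituent on the phenyl, since a 1.9-fold lower number from compound 2 to compound 3 (0.28 log units; within the scatter) does not separate furan-2-yl from phenyl. The series also gains its first step beyond the scatter in a 3.8-fold lower number from compound 1 to compound 3 (0.58 log units; beyond the scatter) and this modest step rests on furan-2-yl in place of 4-fluorophenyl, while compound 2 lies within the scatter of both other compounds, so the three numbers form one shallow spread and not separate levels. No measurement is available that would account for this spread.

From the compounds shown here alone, whether another ring at this position, such as thiophen-2-yl, pyridin-2-yl or saturated cyclohexyl, would move the number further from that of compound 1 remains open. The rest of the molecule is the same in all three compounds, so the effect of a longer chain or an amine elsewhere on the shared core is also unknown.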